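Swapping the amide partner on a weakly active core

A few compounds are considered here, and "the series" means these few. Any claim that something is new, unique, unknown or untested is made for them only; others in the source may bear on it.

Compound 1 `CCCSc1nc(Cl)c2c(n1)N(Cc1cccs1)C(C(=O)N1CCN(C)CC1)N2`: 39400 nM
Compound 2 `CCCSc1nc(Cl)c2c(n1)N(Cc1ccccc1)C(C(=O)N1CCN(C)CC1)N2`: 42500 nM

In a functional assay on TE-1 cells (Homo sapiens) for antiproliferative activity, read by MTT assay, with a stated time of 72 h (a higher number here means a weaker inhibitor, a lower number a stronger inhibitor), compound 2 gives 42500 nM. Compound 1 gives 39400 nM, and the step of a 1.1-fold higher number from compound 1 to compound 2 (0.03 log units; within the scatter) lies within the scatter, so the two numbers stand together. Compound 3 `CCCSc1nc(Cl)c2c(n1)N(Cc1ccccc1)C(C(=O)NCCCc1ccccc1)N2` differs from compound 2 in one place: (3-phenylpropyl)amino in place of 4-methylpiperazin-1-yl on a carbonyl carbon. Going by the values given here, the only measured step changes the group on the ring nitrogen, not the carbonyl, so no measured step bears on this change. Compound 3 is therefore expected to sit near the same level, a step of a 1.3-fold lower number from compound 2 to compound 3 (0.12 log units; within the scatter). The estimate for compound 3 is 32000 nM, with a range from 8000 nM to 130000 nM.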

Compound 3, half-maximal inhibitory concentration: 23000 nM
Compound 3: the middle estimate sits 1.4-fold (0.14 log units) above what was measured; low and high end bracket the measured number.
By their numbers in this assay, from the lowest: compounds 3, 1 and 2 (each within the scatter of the next).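

In this assay, the carbonyl position gives a 1.8-fold lower number from compound 2 to compound 3 (0.27 log units; within the scatter). Even an exchange as large as 4-methylpiperazin-1-yl for (3-phenylpropyl)amino, which brings in a hydrogen-bond donor and an aromatic ring of carbon only, therefore leaves the number at the level of the earlier compounds, just as the change on the ring nitrogen did. No supporting measurement bears on this result. On these data alone, whether a shorter benzylamino group, or a carboxylic acid at the end of the propyl chain, would produce a step beyond the scatter remains open.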